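The source may hold more compounds than are shown below. What is called first, only, known or untested is meant among the compounds shown, and "the series" means these compounds.

Two compounds of this series have numbers in an assay on mitochondria for inhibition of Amine oxidase [flavin-containing] A (Rattus norvegicus), tested at 100 uM; on this read-out higher numbers stand for more inhibition at the one concentration tested (going by the name of the read-out) and lower numbers for less inhibition. Compound 1 `NC(=O)[C@H](CO)NCc1ccc(OCc2ccc(Cl)cc2)cc1` gives 47% there. Compound 2 `NC(=O)[C@@H](NCc1ccc(OCc2cccc(Cl)c2)cc1)c1ccccc1` gives 33% in this assay, the lower of the two numbers, below compound 1 by a gap beyond the scatter. Compound 3 `NC(=O)[C@@H](NCc1ccc(OCc2ccccc2)cc1)c1ccccc1` is not yet measured in this assay; against compound 2 it shows the change (hydrogen in place of chloro on an aromatic carbon), that is, 3-chlorobenzyl to benzyl on the benzyloxy group. For the measured compounds named here, no measured pair shows this change, so no sign or size of step is known for it. The expected step from compound 2 to compound 3 in this assay is a number 6 percentage points lower from compound 2 to compound 3 (within the scatter), a drop not clearly beyond the scatter. For compound 3 in this assay the estimate is 27%, with a range from 12% to 44%.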

Compound 3, a percentage reported as inhibition, at one concentration (the size of the read-out at that concentration, not a potency): 35%
Compound 3: middle estimate off by 8 percentage points, on the low side; low and high end bracket the measured number.
By their numbers in this assay, from the lowest: compounds 2 and 3 (each within the scatter of the next); then compound 1.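

For the compounds shown here, compound 2 and compound 3 form the first measured pair for this position, and in this assay hydrogen in place of chloro gives a number 2 percentage points higher from compound 2 to compound 3 (within the scatter). Within this pair, 3-chlorobenzyl and benzyl on the benzyloxy group therefore cannot be told apart, and the chloro is not required for the inhibition seen at this single concentration. Nothing available explains this outcome.

Open, going by these compounds, is whether a larger or different group at this carbon, such as methoxy, nitrile or a carboxylic acid, would shift the number. Also open, on these data alone, is whether chloro elsewhere on this ring would behave the same way.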